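The compounds below may be only part of what the source reports. "The series", "measured", "known", "first", "only" and "open" are said of these compounds alone.

Measured compounds in a physicochemical assay for solubility, in phosphate buffer, with a stated time of 24 h, at pH 7.4; on this read-out higher numbers stand for higher solubility and lower numbers for lower solubility:

Compound 1 `COc1ccc(-c2ccc(OCc3cc(C(=O)NS(=O)(=O)c4ccccc4)oc3C)cc2)nc1` gives 30 ug/mL in this assay.
Compound 2 `Cc1oc(C(=O)NS(=O)(=O)c2ccccc2)cc1COc1ccc(-c2ccc(OC(F)F)cc2)cc1` gives only a limit of this assay, < 0.6 ug/mL.
Compound 3 `COc1ccc(-c2ccc(OCc3cc(C(=O)NS(=O)(=O)c4c(C)noc4C)oc3C)cc2)nc1` gives 90 ug/mL in this assay.

Two changes run through the set. The first separates the cores of compound 1 and compound 3: 3,5-dimethyl-1,2-oxazol-4-yl in place of phenyl on a sulfonyl sulfur. On this change the step is a 3.0-fold higher number from compound 1 to compound 3 (0.48 log units; beyond the scatter), so compound 3 stands highest of the two numbers that were read, with compound 1 nearest to it.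

The second change separates compound 1 from compound 2: 4-(difluoromethoxy)phenyl in place of 5-methoxypyridin-2-yl on an aromatic carbon. Here the step is an at least 50-fold lower number from compound 1 to compound 2 (1.69 log units; beyond the scatter). Its size can only be given as a bound, since compound 2 sits at the limit of < 0.6 ug/mL in this assay, at which 1 of the 3 values shown sits.

Compound 4 `Cc1noc(C)c1S(=O)(=O)NC(=O)c1cc(COc2ccc(-c3ccc(OC(F)F)cc3)cc2)c(C)o1` has not yet been measured in this assay. It differs from compound 3 by 4-(difluoromethoxy)phenyl in place of 5-methoxypyridin-2-yl on an aromatic carbon, which is the same change, at the same place, as that from compound 1 to compound 2. For compound 4 the expected step is a 75-fold lower number from compound 3 to compound 4 (1.88 log units; beyond the scatter), placed beside an at least 50-fold lower number from compound 1 to compound 2 (1.69 log units; beyond the scatter), and this expectation rests on that large measured step together with the starting point of compound 3 at 90 ug/mL. Compound 4 is therefore estimated at 1.2 ug/mL, with a plausible range of 0.3 ug/mL to 4 ug/mL, and a real chance that this assay returns only a limit rather than a number.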

Compound 4, solubility: < 0.6 ug/mL
Compound 4 ended at the assay's limit; the forecaster's own chance of this, stated with the estimate: 50%; middle value at least 2.0-fold (0.30 log units) away from the limit.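

Carried to the core of compound 3, the replacement of 5-methoxypyridin-2-yl by 4-(difluoromethoxy)phenyl again brings a large fall in this assay, with an at least 150-fold lower number from compound 3 to compound 4 (2.17 log units; beyond the scatter) set against an at least 50-fold lower number from compound 1 to compound 2 (1.69 log units; beyond the scatter) on the core of compound 1. This shows that the direction of the change held on both cores shown, but both steps are bounds and not sizes, so it does not show that the change has the same size on each core, and two cores are too few to show that it carries to others. Going by these compounds, the step between the two compounds that bear 4-(difluoromethoxy)phenyl cannot be read, so whether 3,5-dimethyl-1,2-oxazol-4-yl in place of phenyl still raises the number on that side remains unknown, and the two compounds sit at one limit: the limit of < 0.6 ug/mL in this assay, at which 2 of the 4 values shown sit.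

The compounds shown leave open whether the fall goes with the loss of the pyridine ring or with the exchange of methoxy for difluoromethoxy, a question on which 4-methoxyphenyl at the same place would bear. They also leave open whether an amine or a carboxylic acid on that ring would give a readable number on either core.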